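Trifluoromethoxy on the phenyl of compound 2

The source may hold more compounds than are shown below. What is called first, only, known or untested is meant among the compounds shown, and "the series" means these compounds.

In a functional assay on DWD cells (Homo sapiens) for inhibition, read by sulforhodamine B assay (on this read-out higher numbers stand for weaker inhibition of growth and lower numbers for stronger inhibition of growth), compound 1 (`COc1ccc(-c2ccc(-c3ccc(-c4nc5cc(C)ccc5[nH]4)cc3)cc2)cc1OC`) gives 1720 nM and compound 2 (`Cc1ccc2[nH]c(-c3ccc(-c4ccc(-c5ccccc5)cc4)cc3)nc2c1`) gives 28300 nM as the higher of the two numbers. Going by the values given here, the single measured step, a 16-fold higher number from compound 1 to compound 2 (1.22 log units; beyond the scatter) with phenyl in place of 3,4-dimethoxyphenyl on an aromatic carbon, is large and beyond the scatter.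

Compound 3 (`Cc1ccc2[nH]c(-c3ccc(-c4ccc(-c5ccc(OC(F)(F)F)cc5)cc4)cc3)nc2c1`) starts from compound 2 and turns its phenyl into 4-(trifluoromethoxy)phenyl. The change is trifluoromethoxy in place of hydrogen on an aromatic carbon in the form of trifluoromethoxy in place of hydrogen on an aromatic carbon, para to a large group.

Only the measured step bears on this, and only loosely, since it concerns a different substituent. It does show that the bare phenyl of compound 2 goes with the weaker inhibition of growth, while the substituted ring of compound 1 at 1720 nM goes with the stronger. Among the compounds with values here, no trifluoromethoxy compound has been measured, so a lower number is expected, but a smaller shift than the one seen for compound 1. The expected change is a 4.7-fold lower number from compound 2 to compound 3 (0.67 log units; beyond the scatter) ( toward stronger inhibition of growth). For compound 3 the estimated value in this assay is 6000 nM (expected range 1500 nM to 25000 nM).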

Compound 3, concentration for 50% growth inhibition: 41100 nM
For compound 3 the middle estimate is 6.9-fold (0.84 log units) below the measured one, and the stated range ends below it.
By their numbers in this assay, from the lowest: compound 1; then compounds 2 and 3 (each within the scatter of the next).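

In this assay, trifluoromethoxy in place of hydrogen, on an aromatic carbon para to a large group, gives a 1.5-fold higher number from compound 2 to compound 3 (0.16 log units; within the scatter). On this read-out, this substituent therefore cannot be told apart from the hydrogen of the bare phenyl, so the substituted ring of compound 1 does not stand for substituted rings at this position in general. The comparison between the two substituted rings gives a 24-fold higher number from compound 1 to compound 3 (1.38 log units; beyond the scatter), which shows that the separation depends on which group the ring carries, and no supporting data are available to explain why the 3,4-dimethoxyphenyl ring differs from the 4-(trifluoromethoxy)phenyl ring.

On these data alone, it remains open whether both methoxy groups of compound 1 are needed, or whether a single methoxy group on this ring would give a number that groups with compound 1 rather than with compound 2 and compound 3. Also open, as far as these compounds go, is whether an amine or a carboxylic acid in place of hydrogen on this aromatic carbon would give a step beyond the scatter from compound 2.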